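The source may hold more compounds than are shown below. What is called first, only, known or untested is meant among the compounds shown, and "the series" means these compounds.

The measured compounds:

compound 1, `Nc1nc(=O)n(COCCO)cc1[N+](=O)[O-]`, in a functional assay (Oryctolagus cuniculus) for inhibition (a lower number here means a stronger inhibitor, a higher number a weaker inhibitor), gives > 400 ug/mL, a limit of the assay and not a number.
compound 2, `O=c1[nH]c(=O)n(COCCO)cc1/C=C/Br`, in this assay gives > 400 ug/mL, again a limit and not a number.
compound 3, `Nc1nc2c(nc(Br)n2COCCO)c(=O)[nH]1`, in this assay gives 225 ug/mL.

Compound 3 is thus the only one of the three with a number in this assay; the other two values sit at the limit of > 400 ug/mL in this assay, at which 2 of the 3 values shown sit, so no ordering among the three is possible beyond noting that compound 3 alone gives a readable figure.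

Compound 4, `Nc1nc2c(nc(I)n2COCCO)c(=O)[nH]1`, has not yet been measured in this assay. It differs from compound 3 in one place: iodo in place of bromo on an aromatic carbon. This is a swap of one halogen for a neighbouring heavier halogen at the same spot, and no comparison between two measured compounds shows what such a swap does here. The expected step in this assay is therefore small, with no direction favoured, and within the usual scatter of repeated measurements. Compound 4 is expected to give 200 ug/mL, in the range 100 ug/mL to 400 ug/mL, which means an expected step of a 1.1-fold lower number from compound 3 to compound 4 (0.05 log units; within the scatter).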

Compound 4, concentration for 50% inhibition: >= 250 ug/mL
Compound 4 was reported as a limit; the forecaster's own chance of this, stated with the estimate: 25%; middle value at least 1.2-fold (0.09 log units) away from the limit.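

In this assay, going by these compounds alone, iodo in place of bromo on an aromatic carbon, between two ring nitrogen atoms, gives the first comparison at this position: an at least 1.1-fold higher number from compound 3 to compound 4 (0.04 log units; that floor lies within the scatter). Going by these compounds, the reading for compound 4 is a limit of the assay and not a number, so this step is only a floor and its true size stays unknown: the limit of >= 250 ug/mL in this assay, at which 1 of the 4 values shown sits. Within the data shown here, what the pair does show is that this change of halogen brought no stronger inhibition in this assay, while the earlier compounds offered no pair from which to judge any change at this position.

On these data alone, whether chloro, an amine or a longer chain at this position would give a lower number remains open. Also open, as far as these compounds go, is how the reading of compound 3 would respond to a carboxylic acid in place of the (2-hydroxyethoxy)methyl group.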